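Swapping furan for thiophene in a chalcone series

The source may report more compounds than this note shows. Statements on the series, on what has been measured and on what is new or still open speak of the compounds shown alone.

The four compounds share an enone linking two aromatic pieces. Compound 1 `O=C(/C=C/c1ccco1)c1ccccc1OCC1CO1` and compound 2 `O=C(/C=C/c1cccs1)c1ccccc1OCC1CO1` carry an oxiranylmethoxy group on the aryl ketone side, while compound 3 `O=C(/C=C/c1ccc(OCC(O)CCl)cc1)c1ccco1` and compound 4 `O=C(/C=C/c1ccc(OCC(O)CCl)cc1)c1cccs1` carry a chlorohydrin ether on the other aryl ring; the difference between the two cores is not broken down here.

In a functional assay on MDA-MB-231 cells (Homo sapiens) for inhibition, read by CCK-8 assay and cell counting, with a stated time of 2 days (on this read-out higher numbers stand for weaker inhibition and lower numbers for stronger inhibition), compound 1 gives 28700 nM and compound 2 gives 17900 nM. The change between them is thiophen-2-yl in place of furan-2-yl on a double-bonded chain carbon bound to a double-bonded chain carbon, and it produced a 1.6-fold lower number from compound 1 to compound 2 (0.21 log units; within the scatter). For compound 3 only a limit is recorded in this assay, > 50000 nM, a limit at which (the limit of > 50000 nM in this assay, at which 1 of the 3 values shown sits).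

Compound 4 differs from compound 3 by thiophen-2-yl in place of furan-2-yl on a carbonyl carbon. The place is not the same as in the earlier pair: there the thiophen-2-yl entered on a double-bonded chain carbon bound to a double-bonded chain carbon, whereas here it enters on a carbonyl carbon whose other neighbours are a double-bonded chain carbon, so it is the same kind of change rather than the same change. That change is expected to amount to a step that the limit leaves unreadable from compound 3 to compound 4, resting on the step from compound 1 to compound 2 lying within the scatter. Since compound 3 shows only a limit, compound 4 is expected to give roughly 60000 nM in this assay, plausibly between 25000 nM and 150000 nM, with a fair chance that only a limit is reported again.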

Compound 4, half-maximal inhibitory concentration: 30300 nM
The estimate for compound 4 lay 2.0-fold (0.30 log units) above the measured number; low and high end bracket the measured number.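

In this assay, thiophen-2-yl in place of furan-2-yl on a carbonyl carbon gives an at least 1.6-fold lower number from compound 3 to compound 4 (0.21 log units; that floor lies within the scatter), so the second core gives no reading beyond the scatter for this change, although the step could be larger than that floor. Set beside the first pair, the change points the same way on both cores, but neither step establishes a real effect, and the comparison goes only as far as the limit allows: the same change on two cores in this assay, a 1.6-fold lower number (0.21 log units; within the scatter) from compound 1 to compound 2 and an at least 1.6-fold lower number (0.21 log units; that floor lies within the scatter) from compound 3 to compound 4; the limit leaves it open whether they differ This does not show how large the step from compound 3 to compound 4 really is, nor that the change carries over from one core to the other with the same size, and the reading rests on a value that is only a limit: the limit of > 50000 nM in this assay, at which 1 of the 4 values shown sits.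

The compounds shown hold only furan-2-yl and thiophen-2-yl at the changing place, which leaves open how a phenyl or pyridine ring there would read, or how an amine in place of the chlorine of the chlorohydrin ether would. As far as these compounds go, how the oxiranylmethoxy and chlorohydrin ether groups compare also stays open; the two cores differ in more than one place.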